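Series notes: from compound 2 to compound 4

The compounds below may be only part of what the source reports. "The series", "measured", "known", "first", "only" and "open" are said of these compounds alone.

Values in an ADME assay on ECV-304 cells (Homo sapiens) for cytotoxicity, read by MTT assay, with a stated time of 72 h (a higher number here means a weaker inhibitor, a lower number a stronger inhibitor), each of them a limit:
compound 1 `COc1ccc(C2=C(c3cc(OC)c(OC)c(OC)c3)C(=O)C(OC(C)=O)C2)cc1OC(C)C` gives > 100 ug/mL (limit)
compound 2 `COc1ccc(C2=C(c3cc(OC)c(OC)c(OC)c3)C(=O)CC2O[SiH2]C(C)(C)C)cc1` gives > 100 ug/mL (limit)
compound 3 `COc1ccc(C2=C(c3cc(OC)c(OC)c(OC)c3)C(=O)C(O)C2)cc1` gives < 1 ug/mL (limit)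

Compound 2 stands at > 100 ug/mL as a limit and not as a number. The three values occupy two places only: the limit of > 100 ug/mL in this assay, at which 2 of the 3 values shown sit, and the limit of < 1 ug/mL in this assay, at which 1 of the 3 values shown sits, are the whole picture so far.

Compound 4 `COc1cc(C2=C(c3ccccc3)C(O[SiH2]C(C)(C)C)CC2=O)cc(OC)c1OC` follows from compound 2 by one change: hydrogen in place of methoxy on an aromatic carbon (hydrogen in place of methoxy on an aromatic carbon, 4-methoxyphenyl to phenyl). Within the data shown here, no measured step covers this change. The expected step of a number no higher from compound 2 to compound 4 (the limit leaves the size open) stays within the scatter, with no direction expected. For compound 4 the estimated value is 100 ug/mL in the expected range 30 ug/mL to 300 ug/mL for this read-out.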

Compound 4, half-maximal inhibitory concentration: > 100 ug/mL
Compound 4: a limit, no number; the forecaster's own chance of this, stated with the estimate: 70%; the middle value lies on the limit itself.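

Compound 2 and compound 4 are each known only as a limit, and no step can be read between them. The compounds shown leave open whether hydrogen in place of methoxy on an aromatic carbon changes the value at all.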